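The compounds below may be only part of what the source reports. "The series", "measured", "known", "first", "only" and "open" are said of these compounds alone.

Compound 1 `C#Cc1cn([C@@H]2O[C@H](CO)[C@@H](O)[C@H]2O)c2ncnc(SC)c12`: 90 nM
Compound 2 `C#Cc1cn([C@@H]2O[C@H](CO)[C@@H](O)[C@H]2O)c2ncnc(N(C)C)c12`: 290 nM
Compound 3 `Cc1nc(N)c2c(-c3ccoc3)cn([C@@H]3O[C@H](CO)[C@@H](O)[C@H]3O)c2n1`: > 20000 nM

These three ribonucleoside-like compounds were tested in a functional assay on HCT-116 cells (Homo sapiens), read by MTT assay, with a stated time of 72 h; on this read-out lower numbers stand for stronger inhibition and higher numbers for weaker inhibition. In this assay compound 3 reads > 20000 nM, which is a limit of the assay and not a number. That reading is the limit of > 20000 nM in this assay, at which 1 of the 3 values shown sits.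

Compound 4 `Cc1nc(N)c2c(-c3ccccc3)cn([C@@H]3O[C@H](CO)[C@@H](O)[C@H]3O)c2n1` is the next to consider. It carries phenyl in place of furan-3-yl on an aromatic carbon of a five-membered aromatic ring with 1 nitrogen, part of a fused or bridged system of two rings: phenyl in place of furan-3-yl on an aromatic carbon.

Among the measured compounds shown here, only one measured step is available, a 3.2-fold higher number from compound 1 to compound 2 (0.51 log units; beyond the scatter). It exchanges dimethylamino for methylsulfanyl, so it involves neither group at issue here and bears on this change only as a rough guide to how far a single exchange can move the number. For the measured compounds named here, no measured pair exchanges one aromatic ring for another. The expectation therefore rests mainly on compound 3 and its limit, and a modest exchange from that starting point should leave the number in the same region.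

The expected change, which is only an estimate, is a number no higher from compound 3 to compound 4 (the limit leaves the size open). Compound 4 is estimated at 20000 nM, with an expected range from 8000 nM to 40000 nM.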

Compound 4, half-maximal inhibitory concentration: > 20000 nM
Compound 4: no number, only a limit; the forecaster's own chance of this, stated with the estimate: 80%; the middle value sits exactly at the limit.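

In this assay compound 4 gives > 20000 nM, which is a limit and not a number. Compound 3 gives > 20000 nM, also a limit, and no step can be read between compound 3 and compound 4. The compounds shown leave open how phenyl and furan-3-yl compare in this assay, as neither has a number here.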